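Cytotoxicity when a benzyl ester becomes a free acid

This account rests on a few compounds, and the source may have more. Where it says the series, first, only, none or still open, it means among the compounds named here.

Compound 1, `Cc1cn([C@@H]2O[C@H](CO[Si](C)(C)C(C)(C)C)[C@@]3(OS(=O)(=O)C=C3NCCC(=O)OCc3ccccc3)[C@H]2O[Si](C)(C)C(C)(C)C)c(=O)n(C)c1=O`: > 250000 nM
Compound 2, `COC(=O)CC(=O)NC1=CS(=O)(=O)O[C@@]12[C@@H](CO[Si](C)(C)C(C)(C)C)O[C@@H](n1cc(C)c(=O)n(C)c1=O)[C@@H]2O[Si](C)(C)C(C)(C)C`: 11900 nM
Compound 3, `C=C(C)C(=O)NC(=O)NC1=CS(=O)(=O)O[C@@]12[C@@H](CO[Si](C)(C)C(C)(C)C)O[C@@H](n1cc(C)c(=O)n(C)c1=O)[C@@H]2O[Si](C)(C)C(C)(C)C`: 1190 nM

All three compounds share one core and differ only in the group on the amine nitrogen. In a functional assay on MT4 cells (Homo sapiens) (a higher number here means that more compound is tolerated, a lower number that less compound is tolerated), compound 1 reaches only a limit, > 250000 nM, and no number is known for it (the limit of > 250000 nM in this assay, at which 1 of the 3 values shown sits). In this assay compound 2 gives 11900 nM, and compound 3 gives 1190 nM. The measured steps from compound 1 are both large: an at least 21-fold lower number from compound 1 to compound 2 (1.32 log units; beyond the scatter) and an at least 210-fold lower number from compound 1 to compound 3 (2.32 log units; beyond the scatter). Between the two acylated compounds the step is a 10-fold lower number from compound 2 to compound 3 (1.00 log units; beyond the scatter).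

Compound 4, `Cc1cn([C@@H]2O[C@H](CO[Si](C)(C)C(C)(C)C)[C@@]3(OS(=O)(=O)C=C3NCC(=O)O)[C@H]2O[Si](C)(C)C(C)(C)C)c(=O)n(C)c1=O`, is the unmeasured compound. Its change from compound 1 is carboxy in place of (benzyloxycarbonyl)methyl on a saturated chain carbon bound to an amine nitrogen. Both measured steps from compound 1 replace the whole 2-(benzyloxycarbonyl)ethyl with a carbonyl-bearing group on the amine nitrogen; in compound 4 the amine nitrogen keeps a saturated chain carbon, so neither step covers this change closely. For compound 4 in this assay a step of an at least 1.2-fold lower number from compound 1 to compound 4 (0.09 log units; that floor lies within the scatter) is therefore expected, within the scatter or at most modest, with a good chance that the assay again reports only a limit. The estimate for compound 4 is 200000 nM, between 60000 nM and 400000 nM.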

Compound 4, half-maximal cytotoxic concentration: 30000 nM
Estimate against measurement, compound 4: 6.7-fold (0.82 log units) above; the measured number lies below the stated range.
By their numbers in this assay, from the lowest: compound 3; then compound 2; then compound 4. At a limit, above all of these: compound 1.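

In this assay, the change from 2-(benzyloxycarbonyl)ethyl to carboxymethyl gives an at least 8.3-fold lower number from compound 1 to compound 4 (0.92 log units; beyond the scatter), so this position responds even when a saturated chain carbon stays on the amine nitrogen, and a carbonyl directly on that nitrogen, as in compound 2 and compound 3, is not required for a step beyond the scatter. The new compound still has the highest number of those with a measured value, with a 2.5-fold higher number from compound 2 to compound 4 (0.40 log units; beyond the scatter) and a 25-fold higher number from compound 3 to compound 4 (1.40 log units; beyond the scatter), so it lies much closer to the malonyl-type amide of compound 2 than to the acylurea-like group of compound 3. Compound 1 stands at a limit of the assay, so the first of these steps has only a lower bound: the limit of > 250000 nM in this assay, at which 1 of the 4 values shown sits.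

The compounds shown leave open which part of the change carries the step, as the loss of the benzyl group and the shorter chain come together in compound 4. A free carboxylic acid on the longer ethyl chain, or a benzyl ester on the shorter methyl chain, would separate the two, and an amine in place of the acid would show whether the acid itself matters.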